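A few compounds are considered here, and "the series" means these few. Any claim that something is new, unique, unknown or untested is made for them only; others in the source may bear on it.

Compound 1, `O=c1[nH]c(=O)n(COCCO)cc1[N+](=O)[O-]`, gives in a functional assay on L1210 cells (Mus musculus) for inhibition (on this read-out higher numbers stand for weaker inhibition and lower numbers for stronger inhibition), a limit rather than a number: > 1000 ug/mL.
Compound 2, `Nc1nc(=O)ccn1COCCO`, gives in this assay likewise only a limit: > 500 ug/mL.
Compound 3, `CC(=O)OCCOCn1cnc2c(Cl)ncnc21`, gives in this assay 233 ug/mL.

Among the three, compound 3 is therefore the only one with an actual number. Compound 1 sits at the limit of > 1000 ug/mL in this assay, at which 1 of the 3 values shown sits. Compound 2 sits at the limit of > 500 ug/mL in this assay, at which 1 of the 3 values shown sits. Among the measured compounds shown here, no two measured compounds differ in a single place, so no step between them can be read off, and the series offers no measured step on which to rest a forecast.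

Compound 4, `CC(=O)OCCOCn1cnc2c(Cl)nc(Cl)nc21`, is the next compound. It differs from compound 3 by chloro in place of hydrogen on an aromatic carbon. For the measured compounds named here, with no measured step to lean on, the expectation is a modest move toward stronger inhibition, a 2.3-fold lower number from compound 3 to compound 4 (0.37 log units; beyond the scatter), which is estimated to sit at or only a little beyond the usual scatter. Compound 4 is accordingly expected to give 100 ug/mL, within a range from 30 ug/mL to 400 ug/mL.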

Compound 4, concentration for 50% inhibition: 98 ug/mL
For compound 4 the middle estimate is 1.0-fold (0.01 log units) above the measured one, and the stated range covers the measured number.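

Chloro in place of hydrogen on an aromatic carbon, between two ring nitrogen atoms, gives in this assay a 2.4-fold lower number from compound 3 to compound 4 (0.38 log units; beyond the scatter), the first step in the series that can be read at all. The step is modest but lies beyond the scatter, so this position on the six-membered aromatic ring with 2 nitrogen tolerates chloro and the change goes toward stronger inhibition. Nothing measured here bears on why this step occurs.

The compounds shown leave open how an amine or a bromo group at this same position would read, and so whether the move is particular to chloro. They also leave open whether the step would carry over to a longer chain in place of the acetate-bearing one.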